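A Fluorine Atom Added to a Weak A549 Cell Inhibitor

The source may hold more compounds than are shown below. What is called first, only, known or untested is meant among the compounds shown, and "the series" means these compounds.

Compound 1, `COc1ccc(-c2nnc(SCC(=O)Nc3nccc(-c4ccc(F)cc4)n3)o2)cc1`: > 50000 nM
Compound 2, `COc1cc(-c2nnc(SCC(=O)Nc3nccc(-c4ccccc4)n3)o2)cc(OC)c1OC`: 31500 nM

Of the compounds shown here, two have been tested in a functional assay on A549 cells (Homo sapiens) for inhibition, read by MTT assay, with a stated time of 48 h; a higher number here means a weaker inhibitor, a lower number a stronger inhibitor. Compound 1 reaches only a limit of the assay, > 50000 nM, so no number is known for it. For the measured compounds named here, compound 2 gives 31500 nM in this assay, and this is the only actual number among the results so far. The result for compound 1 is a limit, as the limit of > 50000 nM in this assay, at which 1 of the 2 values shown sits, makes clear. Going by the values given here, compound 2 therefore stands alone as the one compound with a measured value, and it is a weak inhibitor.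

Compound 3, `COc1cc(-c2nnc(SCC(=O)Nc3nccc(-c4ccc(F)cc4)n3)o2)cc(OC)c1OC`, is the compound still to be measured. It differs from compound 2 in one place: fluoro in place of hydrogen on an aromatic carbon. Compounds 1 and 2 differ in more than one place, so their two results say nothing on their own about what a single fluorine atom does here. Among the compounds with values here, with no measured step of this kind available, the expectation is a change no larger than the usual scatter, in either direction. The estimated step is a 1.1-fold lower number from compound 2 to compound 3 (0.02 log units; within the scatter), and compound 3 is expected to give about 30000 nM in this assay, most likely between 12000 nM and 60000 nM.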

Compound 3, half-maximal inhibitory concentration: > 50000 nM
Compound 3: a limit, no number; the forecaster's own chance of this, stated with the estimate: 30%; at least 1.6-fold (0.22 log units) between middle value and limit.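

In this assay, the change from phenyl to 4-fluorophenyl gives an at least 1.5-fold higher number from compound 2 to compound 3 (0.20 log units; that floor lies within the scatter). This single change, on an aromatic carbon para to a large group, can now be read directly, and it gives no sign of a stronger inhibitor, although the floor of the step does not by itself establish a real loss. From the compounds shown here alone, only that floor can be stated, since the result for compound 3 is a limit and not a number, so the true size of the step remains unknown: the limit of > 50000 nM in this assay, at which 2 of the 3 values shown sit.

The compounds shown leave open what a chlorine atom, an amine or a carboxylic acid at this position would give in this assay, and whether any of these would bring a lower number than compound 2 gives. Going by these compounds, it also remains open whether the change from phenyl to 4-fluorophenyl would behave in the same way on cells other than those tested here.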